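Swapping the Group on the Carbonyl Carbon

The source may report more compounds than this note shows. Statements on the series, on what has been measured and on what is new or still open speak of the compounds shown alone.

Three compounds have been measured in a functional assay on isolated protein for inhibition of Glucose-dependent insulinotropic receptor (Rattus norvegicus), read by HTRF and cAMP accumulation; a lower number here means that less compound is needed, a higher number that more compound is needed for the effect:

Compound 1, `Cc1nc(S(C)(=O)=O)ccc1Oc1ncnc(OC2CCN(C(=O)OC3CCC3)CC2)c1F`: 167 nM
Compound 2, `Cc1nc(S(C)(=O)=O)ccc1Oc1ncnc(OC2CCN(C(=O)OC3(C(F)(F)F)CCC3)CC2)c1F`: 63.3 nM
Compound 3, `Cc1nc(S(C)(=O)=O)ccc1Oc1ncnc(OC2CCN(C(=O)SC3(C)CC3)CC2)c1F`: 166 nM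

Compound 3 stands second highest of the three: its number sits within the scatter of compound 1, while compound 2 lies lower, as shown by the step of a 2.6-fold higher number from compound 2 to compound 3 (0.42 log units; beyond the scatter). Compound 4, `CCc1cnc(C(=O)N2CCC(Oc3ncnc(Oc4ccc(S(C)(=O)=O)nc4C)c3F)CC2)nc1`, differs from compound 3 only at the carbonyl carbon: a group of 8 heavy atoms (6 carbon, 2 nitrogen; one six-membered aromatic ring with 2 hetero atoms) in place of a group of 5 heavy atoms (4 carbon, 1 sulfur; one three-membered non-aromatic ring of carbon only), on a carbonyl carbon. The measured steps that bear on this position are a 1.0-fold lower number from compound 1 to compound 3 (0.00 log units; within the scatter) and a 2.6-fold higher number from compound 2 to compound 3 (0.42 log units; beyond the scatter). Within the data shown here, neither was more than modest, and no measured compound carries an aromatic ring at that carbonyl carbon, so no step beyond the scatter is expected here; the estimated change is a 1.1-fold lower number from compound 3 to compound 4 (0.04 log units; within the scatter). Compound 4 is therefore expected to give 150 nM, with a range from 50 nM to 450 nM.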

Compound 4, half-maximal effective concentration: 40.8 nM
Compound 4: middle estimate off by 3.7-fold (0.57 log units), on the high side; the measured number lies below the stated range.
By their numbers in this assay, from the lowest: compounds 4 and 2 (each within the scatter of the next); then compounds 3 and 1 (each within the scatter of the next).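

An aromatic ring is accepted on this carbonyl carbon, and 5-ethylpyrimidin-2-yl does better than two of the earlier groups, with a 4.1-fold lower number from compound 3 to compound 4 (0.61 log units; beyond the scatter) and a 4.1-fold lower number from compound 1 to compound 4 (0.61 log units; beyond the scatter). Against the group carrying trifluoromethyl, the step is a 1.6-fold lower number from compound 2 to compound 4 (0.19 log units; within the scatter), so two very different groups give matching results at this place. Nothing shown gives a reason for these steps.

As far as these compounds go, what the ethyl chain contributes remains open, as does whether a phenyl ring or an unsubstituted pyrimidin-2-yl would serve equally well here.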